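Amino in place of chloro across two benzyl isomers

The source may report more compounds than this note shows. Statements on the series, on what has been measured and on what is new or still open speak of the compounds shown alone.

Compound 1 `ClCc1ccccc1Cn1cnc2c(Cl)nc(Cl)nc21` and compound 2 `ClCc1cccc(Cn2cnc3c(Cl)nc(Cl)nc32)c1` contain the same atoms joined differently; the difference between the two cores is not broken down here. In a functional assay on SF-539 cells (Homo sapiens) for cytotoxicity, read by sulforhodamine B assay, with a stated time of 48 h (a higher number here means that more compound is tolerated, a lower number that less compound is tolerated), compound 1 gives 5620 nM, and compound 2 gives 40700 nM. Compound 3 `Nc1nc(Cl)c2ncn(Cc3ccccc3CCl)c2n1` is derived from compound 1 by amino in place of chloro on an aromatic carbon. In this assay, among the measured compounds shown here, compound 3 gives 81300 nM, so the step of a 14-fold higher number from compound 1 to compound 3 (1.16 log units; beyond the scatter) is the only measured instance of this change. Compound 2 and compound 3 lie within the usual scatter of each other, so nothing is said about their order.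

Compound 4 `Nc1nc(Cl)c2ncn(Cc3cccc(CCl)c3)c2n1` has not yet been measured. It differs from compound 2 by amino in place of chloro on an aromatic carbon, the same change as that from compound 1 to compound 3, at a place described in identical words on the core of compound 2. The change has been seen once only, and on the other core. For compound 4 the expected step is a 6.1-fold higher number from compound 2 to compound 4 (0.79 log units; beyond the scatter), smaller than the measured one. For the measured compounds named here, this rests on compound 2 already standing at 40700 nM, well above compound 1 at 5620 nM, and on the single instance a 14-fold higher number from compound 1 to compound 3 (1.16 log units; beyond the scatter) carrying no information about how the change behaves when the starting number is already high. In this assay compound 4 is expected to give about 250000 nM, with a range from 80000 nM to 800000 nM.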

Compound 4, concentration lethal to 50% of the cells: 69200 nM
Beside the measured number, compound 4's estimate is 3.6-fold (0.56 log units) above it, and the stated range ends above it.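

Among the compounds shown here, on the core of compound 2, amino in place of chloro on an aromatic carbon gives a 1.7-fold higher number from compound 2 to compound 4 (0.23 log units; within the scatter), so in this assay this change leaves no step there that can be told apart from the scatter. The large step seen on the core of compound 1 therefore does not carry over at the same size to the core of compound 2, and the two instances clearly differ: the same change on two cores in this assay, a 14-fold higher number (1.16 log units; beyond the scatter) from compound 1 to compound 3 and a 1.7-fold higher number (0.23 log units; within the scatter) from compound 2 to compound 4, 8.5-fold (0.93 log units) apart, beyond the scatter of two such steps

With a single instance on each core, this shows only that the size of the step depends on the core in this pair; it does not show what in the two cores sets the steps apart, nor which size would hold on any further core in the series.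

Open, on these data alone, is whether the same split between the two cores would appear with another group in place of the chloro group on that aromatic carbon, such as a methylamino or a methoxy group. Also open, as far as these compounds go, is whether it depends on the chloromethyl group that both cores carry, which a hydroxymethyl or a plain methyl group in its place would test.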